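Adding a Second Nitro Group: Expected Effect on Inhibition

A few compounds are considered here, and "the series" means these few. Any claim that something is new, unique, unknown or untested is made for them only; others in the source may bear on it.

Compound 1 `O=C(NN=C1CC(c2ccccc2)NC(c2ccccc2)C1)c1ccccc1`: 41900 nM
Compound 2 `O=C(NN=C1CC(c2ccccc2)NC(c2ccccc2)C1)c1ccc([N+](=O)[O-])cc1`: 45200 nM

In a functional assay for inhibition, read by spectrophotometry, with a stated time of 120 min (a higher number here means a weaker inhibitor, a lower number a stronger inhibitor), compound 2 gives 45200 nM. Among the two numbers shown, its nearest neighbour is compound 1, and the gap between them, a 1.1-fold higher number from compound 1 to compound 2 (0.03 log units; within the scatter), lies within the scatter. Compound 3 `O=C(NN=C1CC(c2ccccc2)NC(c2ccccc2)C1)c1ccc([N+](=O)[O-])cc1[N+](=O)[O-]` differs from compound 2 by nitro in place of hydrogen on an aromatic carbon. Among the measured compounds shown here, the only measured step that bears on this change is a 1.1-fold higher number from compound 1 to compound 2 (0.03 log units; within the scatter), the same kind of replacement, which left the number essentially unchanged. The step to compound 3 is therefore expected to be small, a 1.1-fold higher number from compound 2 to compound 3 (0.04 log units; within the scatter), with no direction beyond the scatter. Compound 3 is estimated at 50000 nM, with a range from 20000 nM to 125000 nM.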

Compound 3, half-maximal inhibitory concentration: 28200 nM
The estimate for compound 3 lay 1.8-fold (0.25 log units) above the measured number, and the stated range covers the measured number.
By their numbers in this assay, from the lowest: compounds 3, 1 and 2 (each within the scatter of the next).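

The same replacement on this aromatic carbon, ortho to a large group and meta to a nitro group, gives a 1.6-fold lower number from compound 2 to compound 3 (0.20 log units; within the scatter) in this assay, so a second nitro group, like the first, does not move the number beyond the scatter. No measured evidence on the cause of this small step is available. The compounds shown leave open whether an amine or a carboxylic acid in place of either nitro group would shift the number beyond the scatter, and whether changes elsewhere on the shared core would do so.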